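Moving a chlorine from compound 3 to compound 4

The compounds below may be only part of what the source reports. "The series", "measured", "known", "first", "only" and "open" are said of these compounds alone.

In a functional assay on MDA-MB-231 cells (Homo sapiens) for antiproliferative activity, read by MTT assay, with a stated time of 24 h (on this read-out lower numbers stand for stronger inhibition and higher numbers for weaker inhibition), compound 1 (`O=C(NNc1ccccc1Cl)c1ccc(NS(=O)(=O)c2cnc(O)nc2O)cc1`) gives 4010 nM and compound 2 (`O=C(NNc1cccc(Cl)c1)c1ccc(NS(=O)(=O)c2cnc(O)nc2O)cc1`) gives 17400 nM while compound 3 (`O=C(NNC(=O)c1ccccc1Cl)c1ccc(NS(=O)(=O)c2cnc(O)nc2O)cc1`) gives 13900 nM on the same scale. Compound 3 sits among the higher numbers: there is a 1.3-fold lower number from compound 2 to compound 3 (0.10 log units; within the scatter) and so no real gap, whereas there is a 3.5-fold higher number from compound 1 to compound 3 (0.54 log units; beyond the scatter) and so a real one.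

Compound 4 (`O=C(NNC(=O)c1cccc(Cl)c1)c1ccc(NS(=O)(=O)c2cnc(O)nc2O)cc1`) carries 3-chlorophenyl in place of 2-chlorophenyl on a carbonyl carbon. For the measured compounds named here, the nearest precedent is the same swap on an amine nitrogen, which gave a 4.3-fold higher number from compound 1 to compound 2 (0.64 log units; beyond the scatter) and is the only such pair available. That step began at the lowest number of the three, whereas compound 3 already stands high, so a smaller move in the same upward direction seems likely. The expected change is a 1.4-fold higher number from compound 3 to compound 4 (0.16 log units; within the scatter) in this assay and would amount to little. For compound 4 the estimate is 20000 nM with an expected range from 7000 nM to 50000 nM for repeat measurements.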

Compound 4, half-maximal inhibitory concentration: 4160 nM
Compound 4: the middle estimate sits 4.8-fold (0.68 log units) above what was measured, outside the stated range (below it).
By their numbers in this assay, from the lowest: compounds 1 and 4 (each within the scatter of the next); then compounds 3 and 2 (each within the scatter of the next).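

In this assay the 3-chlorophenyl for 2-chlorophenyl swap on a carbonyl carbon gives a 3.3-fold lower number from compound 3 to compound 4 (0.52 log units; beyond the scatter) and so runs opposite to the same swap on an amine nitrogen, which gave a 4.3-fold higher number from compound 1 to compound 2 (0.64 log units; beyond the scatter) in the earlier pair. The effect of moving the chlorine therefore depends on what carries the ring, and the added carbonyl also acts differently in the two cases: with the 3-chlorophenyl ring there is a 4.2-fold lower number from compound 2 to compound 4 (0.62 log units; beyond the scatter) while with the 2-chlorophenyl ring there was a 3.5-fold higher number from compound 1 to compound 3 (0.54 log units; beyond the scatter) and the two best-placed compounds show no real gap, with a 1.0-fold higher number from compound 1 to compound 4 (0.02 log units; within the scatter) as their comparison. No measurement shown accounts for this reversal.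

From the compounds shown here alone, whether the reversal is peculiar to chlorine stays open, since a 3-methoxyphenyl or plain phenyl group might follow either trend. A 4-chlorophenyl group on each of the two attachments would also show whether the pattern extends beyond these four compounds.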